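Notes on the azetidinyl-carbamate to pyrrolidinyl step

The compounds below may be only part of what the source reports. "The series", "measured", "known", "first", "only" and "open" are said of these compounds alone.

Two compounds of this series carry a number in an ADME assay on microsomes from liver (Homo sapiens) for metabolic stability; on this read-out higher numbers stand for fast clearance and lower numbers for slow clearance. Compound 1 (`CCc1ccc(-c2c(-c3nn(C)c4ncnc(N5CC(NC(=O)OC)C5)c34)cnn2C)cc1`) gives 42 mL/min/kg in this assay, the lower of the two numbers. Compound 2 (`CC(C)Cc1nn(C)c2ncnc(N3Cc4ccccc4C3)c12`), a differently substituted analogue on the same core, gives 123 mL/min/kg in this assay, and the gap between compound 1 and compound 2 lies beyond the scatter. Within the data shown here, no pair of the two differs in only one place, so no single step has been measured.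

Compound 3 (`CCc1ccc(-c2c(-c3nn(C)c4ncnc(N5CCCC5)c34)cnn2C)cc1`) remains to be measured in this assay. It differs from compound 1 by the change (pyrrolidin-1-yl in place of 3-((methoxycarbonyl)amino)azetidin-1-yl on an aromatic carbon). Nothing measured covers this exact swap; compound 2, which carries no carbamate, is the only other reference and sits higher. On that basis a moderate upward step from compound 1 to compound 3 is expected, of about a 1.7-fold higher number from compound 1 to compound 3 (0.22 log units; within the scatter), with the possibility of no change beyond the scatter. Compound 3 is therefore estimated at 70 mL/min/kg in this assay, within a range of 35 mL/min/kg to 140 mL/min/kg.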

Compound 3, clearance: 200 mL/min/kg
Beside the measured number, compound 3's estimate is 2.9-fold (0.46 log units) below it; measured number outside the range, above it.
By their numbers in this assay, from the lowest: compound 1; then compounds 2 and 3 (each within the scatter of the next).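

In this assay, the position on the aromatic carbon of the six-membered aromatic ring with 2 nitrogen now has its first single-change reading: pyrrolidin-1-yl in place of 3-((methoxycarbonyl)amino)azetidin-1-yl gives a 4.8-fold higher number from compound 1 to compound 3 (0.68 log units; beyond the scatter), with the rest of the structure held constant. The earlier gap between compound 1 and compound 2 spanned more than one place and could not be assigned to any one of them, whereas this step ties a clearance difference to this position alone. No measurement at hand speaks to what lies behind the step, and this one swap alters the ring size and removes the carbamate together, so the two changes cannot be told apart.

Going by these compounds, it remains open which part of the change carries the step, a question that plain azetidin-1-yl or 3-aminoazetidin-1-yl at the same carbon would divide into its parts. On these data alone, it also remains open whether a step of this size would recur with the other substituents of compound 2 on the shared core.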